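Swapping a methyl for hydrogen on compound 3

The source may hold more compounds than are shown below. What is called first, only, known or untested is meant among the compounds shown, and "the series" means these compounds.

In a functional assay on MCF7 cells (Homo sapiens) for cytotoxicity, read by MTT assay, with a stated time of 72 h (a lower number here means a stronger inhibitor, a higher number a weaker inhibitor), compound 1 `Cn1ccc2c(Oc3ccc(NC(=O)c4cc5cccnc5n(-c5ccc(Br)cc5)c4=O)cc3)ncnc21` gives 79400 nM, compound 2 `Cn1ccc2c(Oc3ccc(NC(=O)c4cc5cccnc5n(-c5ccc(Cl)cc5)c4=O)cc3F)ncnc21` gives 75000 nM and compound 3 `Cn1ccc2c(Oc3ccc(NC(=O)c4cc5cccnc5n(-c5ccc(Br)cc5)c4=O)cc3F)ncnc21` gives 59400 nM. Compound 3 therefore sits within the scatter of both of the others, and no order can be drawn among the three.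

The next compound, compound 4 `O=C(Nc1ccc(Oc2ncnc3[nH]ccc23)c(F)c1)c1cc2cccnc2n(-c2ccc(Br)cc2)c1=O`, has hydrogen in place of methyl on an aromatic nitrogen. Two measured steps lead to compound 3. Fluoro in place of hydrogen on an aromatic carbon gives a 1.3-fold lower number from compound 1 to compound 3 (0.13 log units; within the scatter), and bromo in place of chloro on an aromatic carbon gives a 1.3-fold lower number from compound 2 to compound 3 (0.10 log units; within the scatter). Both are small and within the scatter, but neither touches this nitrogen, so the data offer no direct guide to the new change.

With no evidence for a direction, no shift beyond the scatter is expected in this assay. The expected change is a 1.2-fold lower number from compound 3 to compound 4 (0.07 log units; within the scatter). Compound 4 is estimated at 50000 nM, with an expected range of 15000 nM to 100000 nM.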

Compound 4, half-maximal inhibitory concentration: 27000 nM
Estimate against measurement, compound 4: 1.9-fold (0.27 log units) above; low and high end bracket the measured number.
By their numbers in this assay, from the lowest: compound 4; then compounds 3, 2 and 1 (each within the scatter of the next).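

In this assay, hydrogen in place of methyl on the aromatic nitrogen comes with a clear though modest change (a 2.2-fold lower number from compound 3 to compound 4 (0.34 log units; beyond the scatter)). Among these compounds, the earlier steps, on the fluoro and on the bromo in place of chloro, stayed within the scatter, so this nitrogen is the first place in the set where a single change moves the number beyond it. Nothing available here accounts for the shift.

With only methyl and hydrogen shown on this nitrogen, it remains open whether an ethyl group, a longer chain or a chain ending in an amine would lie closer to compound 3 or to compound 4. Going by these compounds, it also remains open whether the same step would appear with chloro in place of bromo, or without the fluoro.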